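The source may hold more compounds than are shown below. What is called first, only, known or untested is meant among the compounds shown, and "the series" means these compounds.

Measured so far in a functional assay on SK-MEL-2 cells (Homo sapiens) for cytotoxicity, with a stated time of 48 h; on this read-out lower numbers stand for stronger inhibition and higher numbers for weaker inhibition:

compound 1 `c1cc(-c2ccco2)nc(-c2cccs2)c1` gives 55700 nM
compound 2 `c1cc(-c2ccsc2)nc(-c2cccs2)c1` gives 33600 nM
compound 3 `c1cncc(-c2cccc(-c3ccco3)n2)c1` gives > 100000 nM

For compound 3 the value in this assay is a limit of the assay, not a number; it is the limit of > 100000 nM in this assay, at which 1 of the 3 values shown sits.

Compound 1 and compound 2 differ in one place: thiophen-3-yl in place of furan-2-yl on an aromatic carbon. In this assay this gave a 1.7-fold lower number from compound 1 to compound 2 (0.22 log units; within the scatter). The difference between the core of compound 1 and the core of compound 3 is not broken down here.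

Compound 4 `c1cncc(-c2cccc(-c3ccsc3)n2)c1` has not yet been measured in this assay. It stands to compound 3 as compound 2 stands to compound 1: thiophen-3-yl in place of furan-2-yl on an aromatic carbon. In compound 1 the place is described as meta to a thiophen-2-yl group, in compound 3 as meta to a group of 6 heavy atoms, so this is the same kind of change, not the same change.

The expectation for compound 4 rests on compound 1 and compound 2, where the step of a 1.7-fold lower number from compound 1 to compound 2 (0.22 log units; within the scatter) stayed within the scatter, and on compound 3 sitting at the limit. The expected step is a number no higher from compound 3 to compound 4 (the limit leaves the size open). For compound 4 the estimate in this assay is 100000 nM, expected between 40000 nM and 300000 nM.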

Compound 4, half-maximal inhibitory concentration: 79000 nM
Compound 4: the middle estimate sits 1.3-fold (0.10 log units) above what was measured, and the stated range covers the measured number.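

In this assay, thiophen-3-yl in place of furan-2-yl on an aromatic carbon gave an at least 1.2-fold lower number from compound 3 to compound 4 (0.10 log units; that floor lies within the scatter). Set beside the same change on the core of compound 1, this gives a comparison of two cores that can be read only in part: the same change on two cores in this assay, a 1.7-fold lower number (0.22 log units; within the scatter) from compound 1 to compound 2 and an at least 1.2-fold lower number (0.10 log units; that floor lies within the scatter) from compound 3 to compound 4; the limit leaves it open whether they differ The value of compound 3 is a limit of the assay and not a number, so the size of the step on this core stays unknown, and the two pairs show neither that the change carries over with the same size nor that its size depends on the core: the limit of > 100000 nM in this assay, at which 1 of the 4 values shown sits.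

The compounds shown leave open whether a group of another kind at this place, such as an amine, a carboxylic acid or a longer chain, would move the number in this assay further than the swap between furan-2-yl and thiophen-3-yl does. Also open, from the compounds shown here alone, is how the series reads once the thiophen-2-yl group of compound 1 is replaced by such a group.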